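The compounds below may be only part of what the source reports. "The series", "measured", "known", "first", "only" and "open" are said of these compounds alone.

Compound 1 `CCc1ccccc1Nc1ncc2cc(Oc3ccnc(C(=O)NC)c3)ccc2n1` gives < 1 10^-6 cm/s in an ADME assay on Caco-2 cells (Homo sapiens) for permeability, in the apical to basolateral direction (on this read-out higher numbers stand for higher permeability and lower numbers for lower permeability), a limit of the assay rather than a number.
Compound 2 `CNC(=O)c1cc(Oc2ccc3nc(Nc4cccc(Cl)c4)ncc3c2)ccn1` gives < 1 10^-6 cm/s in this assay, again a limit.
Compound 3 `CNC(=O)c1cc(Oc2ccc3nc(Nc4ccc(F)cc4)ncc3c2)ccn1` gives < 1 10^-6 cm/s in this assay, again a limit.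

Compound 2 therefore stands at the edge of what this assay can read, as shown by the limit of < 1 10^-6 cm/s in this assay, at which 3 of the 3 values shown sit. Compound 4 `CNC(=O)c1cc(Oc2ccc3nc(Nc4ccc(C(C)C)cc4)ncc3c2)ccn1` differs from it by 4-isopropylphenyl in place of 3-chlorophenyl on a nitrogen on an aromatic ring. The measured steps that touch the same position are a step that the two limits leave unreadable from compound 1 to compound 2, a step that the two limits leave unreadable from compound 1 to compound 3 and a step that the two limits leave unreadable from compound 2 to compound 3; none can be sized because all three values sit at the limit of < 1 10^-6 cm/s in this assay, at which 3 of the 3 values shown sit. Nothing measured points to a readable step, so the expected step is a step that the limit leaves unreadable from compound 2 to compound 4. Compound 4 is estimated at 0.8 10^-6 cm/s, within 0.2 10^-6 cm/s to 3 10^-6 cm/s.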

Compound 4, apparent permeability: < 1 10^-6 cm/s
Compound 4 was reported as a limit; the forecaster's own chance of this, stated with the estimate: 60%; the middle value does not contradict the limit.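

Compound 4 sits at the same limit as compounds 1, 2 and 3 in this assay, so no step from any of them to compound 4 can be read: the limit of < 1 10^-6 cm/s in this assay, at which 4 of the 4 values shown sit.

The compounds shown leave open how large these steps are, and which group on the nitrogen, if any, would give a readable number.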